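Removing the carbamoyl from the pyridine of compound 2

A few compounds are considered here, and "the series" means these few. Any claim that something is new, unique, unknown or untested is made for them only; others in the source may bear on it.

Among the measured compounds shown here, compound 2 `COc1ccc(Br)cc1S(=O)(=O)Nc1cncc(C(N)=O)c1` gives the lowest of the two numbers so far: in an assay on isolated protein for inhibition of alkaline phosphatase, tissue-nonspecific isozyme (Homo sapiens) (a higher number here means a weaker inhibitor, a lower number a stronger inhibitor), compound 2 gives 14 nM, while compound 1 `COc1ccc(C(N)=O)cc1S(=O)(=O)Nc1cccnc1` gives 1490 nM, a gap beyond the scatter, though the two structures differ in two places. Compound 3 `COc1ccc(Br)cc1S(=O)(=O)Nc1cccnc1` arises from compound 2 by hydrogen in place of carbamoyl on an aromatic carbon. For the measured compounds named here, no measured pair isolates this change, so the expected step from compound 2 to compound 3 in this assay, an 8.6-fold higher number from compound 2 to compound 3 (0.93 log units; beyond the scatter), is a guess toward weaker inhibition, probably well beyond the scatter. Compound 3 is therefore estimated at 120 nM, within 30 nM to 600 nM.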

Compound 3, half-maximal inhibitory concentration: 43 nM
For compound 3 the middle estimate is 2.8-fold (0.45 log units) above the measured one, and the stated range covers the measured number.
By their numbers in this assay, from the lowest: compound 2; then compound 3; then compound 1.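

Hydrogen in place of carbamoyl on this aromatic carbon, two atoms from the ring nitrogen, gives a 3.1-fold higher number from compound 2 to compound 3 (0.49 log units; beyond the scatter) in this assay, so the carbamoyl adds to inhibition but compound 3 keeps much of it without that group. At the other place where the compounds differ, bromo in place of carbamoyl gives a 35-fold lower number from compound 1 to compound 3 (1.54 log units; beyond the scatter), a far larger step. Nothing at hand explains either step. From the compounds shown here alone, whether an amine or a carboxylic acid on the same aromatic carbon would match the carbamoyl remains open. So does whether chloro or methyl could stand in for the bromo.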